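The source may hold more compounds than are shown below. What is called first, only, known or untested is meant among the compounds shown, and "the series" means these compounds.

Measured so far in a physicochemical assay for lipophilicity, using the shake flask method, measured as octanol-water partition, at pH 7.4; a higher number here means a more lipophilic compound, a lower number a more polar compound
Compound 1 `CC(C)n1nc(-c2ccnc3[nH]c(C4CCN(CC(=O)N(C)C)CC4)cc23)ccc1=O` gives 2
Compound 2 `CC(C)Cn1cc(-c2ccnc3[nH]c(C4CCN(CC(=O)N(C)C)CC4)cc23)ccc1=O` gives 2
Compound 3 `COc1cc(F)ccc1-c1ccnc2[nH]c(C3CCOCC3)cc12` gives 3.9

Compound 2 stands level with compound 1, within the scatter, and the two share the low end of the three numbers. Compound 3 lies on the higher side of both, beyond the scatter.

Compound 4 `CN(C)C(=O)CN1CCC(c2cc3c(-c4ccc(=O)n(C5CCC5)c4)ccnc3[nH]2)CC1` has not yet been measured. It differs from compound 2 in one place, with cyclobutyl in place of isobutyl on an aromatic nitrogen. That nitrogen belongs to a six-membered aromatic ring with 1 nitrogen, and the group sits ortho to a group of 1 heavy atom and meta to a large group.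

Among the measured compounds shown here, no measured pair here differs in one place only. For the measured compounds named here, the data offer no direct step for this change. Compound 1 at 2 and compound 2 at 2 read level, and on that alone a step within the scatter is expected in this assay, with no firm direction. The estimate for the step is a number 0.10 log units lower from compound 2 to compound 4 (within the scatter) and it is expected to stay within the scatter. For compound 4 the estimated value is 1.9, with an expected range of 1.5 to 2.3.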

Compound 4, distribution coefficient: 1.9
Compound 4: middle estimate and measured number agree at the digits printed; measured number inside the range.
By their numbers in this assay, from the lowest: compounds 4, 1 and 2 (each within the scatter of the next); then compound 3.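

In this assay the exchange of isobutyl for cyclobutyl on the aromatic nitrogen reads as a number 0.10 log units lower from compound 2 to compound 4 (within the scatter) and gives the only step at this position that can be read from the compounds shown. The two groups have the same count of 4 heavy atoms, all carbon, and differ in that cyclobutyl holds one four-membered non-aromatic ring of carbon only, so in this one pair, tying the carbons of the group into a ring leaves the read-out within the usual scatter of repeated measurements. No measurement shown here offers an explanation for this outcome.

As far as these compounds go, what remains open is how the read-out would respond at this nitrogen to groups of another kind, such as an amine, a carboxylic acid or a longer chain, since both groups compared here consist of carbon alone and have the same count of heavy atoms. A single pair also leaves open whether the same exchange would give a comparable step on a different core or with a different group in place of the dimethylamide side chain.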